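Bombesin Receptor Subtype-3 Agonists: A Difluorinated Benzyl Variant

A few compounds are considered here, and "the series" means these few. Any claim that something is new, unique, unknown or untested is made for them only; others in the source may bear on it.

Compound 3 `O=C(O)c1ccccc1-c1ccc(CCc2ncc(CCc3ccccc3)[nH]2)cc1` gives 174 nM in an in vitro functional assay on cells for agonist activity at Bombesin receptor subtype-3 (Mus musculus), read by luminescence and calcium flux (a higher number here means that more compound is needed for the effect, a lower number that less compound is needed), the highest of the three numbers recorded. Compound 1 `CCCCc1cnc(C(CCC)Cc2ccc(-c3ccccc3C(=O)O)cc2)[nH]1` stands nearest with 165 nM, within the scatter, while compound 2 `O=C(O)c1ccccc1-c1ccc(CCc2ncc(CC3CCCC3)[nH]2)cc1` lies furthest at 7.9 nM. For the measured compounds named here, the only measured step at this chain carbon, a 22-fold higher number from compound 2 to compound 3 (1.34 log units; beyond the scatter), shows that exchanges here can be large. Compound 4 `O=C(O)c1ccccc1-c1ccc(CCc2ncc(Cc3cccc(F)c3F)[nH]2)cc1` differs from compound 3 by 2,3-difluorophenyl in place of benzyl on a saturated chain carbon bound to an aromatic carbon. Going by the values given here, no measured step covers this exchange, so the expected step from compound 3 to compound 4 is small, with wide uncertainty because a 22-fold higher number from compound 2 to compound 3 (1.34 log units; beyond the scatter) was large. The estimate for compound 4 is 120 nM in this assay, ranging from 25 nM to 600 nM, an expected change of a 1.5-fold lower number from compound 3 to compound 4 (0.16 log units; within the scatter).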

Compound 4, half-maximal effective concentration: 8 nM
For compound 4 the middle estimate is 15-fold (1.18 log units) above the measured one, outside the stated range (below it).
By their numbers in this assay, from the lowest: compounds 2 and 4 (each within the scatter of the next); then compounds 1 and 3 (each within the scatter of the next).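

The exchange of benzyl for 2,3-difluorophenyl at this position gives a 22-fold lower number from compound 3 to compound 4 (1.34 log units; beyond the scatter) and so shows a large gain from an aromatic group, where the earlier step showed only a loss. The step of a 1.0-fold higher number from compound 2 to compound 4 (0.01 log units; within the scatter) puts 2,3-difluorophenyl level with cyclopentyl, so an aromatic ring here is compatible with the low numbers. Read one bond further out, the change is phenethyl to 2,3-difluorobenzyl, and the compounds shown leave open how much of it belongs to the shorter chain and how much to the two fluorines. Also open, from the compounds shown here alone, is how a chlorophenyl or methoxyphenyl group would fare here. No evidence on what lies behind these numbers is at hand.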